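Tetrazole for fluoroindole at the chain end

The source may report more compounds than this note shows. Statements on the series, on what has been measured and on what is new or still open speak of the compounds shown alone.

For the measured compounds named here, compound 2 `Fc1cccc2c1ccn2CCCCN1CCN(C(c2ccccc2)c2ccccc2)CC1` gives 150 nM in an assay on RPMI-8226 cells for antagonist activity at P2X purinoceptor 7 (Homo sapiens), read by calcium flux (on this read-out lower numbers stand for stronger inhibition and higher numbers for weaker inhibition), the lowest of the two numbers so far; the only other measured member, compound 1 `Cc1cccc2ccn(CCCCN3CCN(C(c4ccccc4)c4ccccc4)CC3)c12`, gives 2300 nM in this assay. Going by the values given here, the single step recorded, a 15-fold lower number from compound 1 to compound 2 (1.19 log units; beyond the scatter), shows that the group on this chain carbon moves the number strongly. Compound 3 `c1ccc(-c2nnnn2CCCCN2CCN(C(c3ccccc3)c3ccccc3)CC2)cc1` carries a different group at the same place: 5-phenyl-1H-tetrazol-1-yl in place of 4-fluoro-1H-indol-1-yl on a saturated chain carbon, four bonds along the chain from an amine nitrogen in a ring. Among the compounds with values here, the step from compound 1 to compound 2 bears on it only in that it marks this position as sensitive; no measured step exchanges the indole itself for another ring system, so the direction is open. A number beyond the scatter is expected, more likely upward, with the estimated step of a 5.3-fold higher number from compound 2 to compound 3 (0.73 log units; beyond the scatter). Compound 3 is therefore estimated at 800 nM in this assay, with a range from 150 nM to 4000 nM.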

Compound 3, half-maximal inhibitory concentration: 3200 nM
Compound 3: the middle estimate sits 4.0-fold (0.60 log units) below what was measured; low and high end bracket the measured number.
By their numbers in this assay, from the lowest: compound 2; then compounds 1 and 3 (each within the scatter of the next).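

In this assay the 5-phenyl-1H-tetrazol-1-yl group in place of 4-fluoro-1H-indol-1-yl gives a 21-fold higher number from compound 2 to compound 3 (1.33 log units; beyond the scatter) and so does not keep the low number of compound 2 at this chain end. Set against the 7-methyl-1H-indol-1-yl group, the same tetrazole gives a 1.4-fold higher number from compound 1 to compound 3 (0.14 log units; within the scatter) and so cannot be told apart from it, which leaves the 4-fluoro-1H-indol-1-yl group alone among the three groups at this place. No measurement at hand offers an explanation for either step.

Open, as far as these compounds go, is whether the low number of compound 2 follows the fluorine or the indole, which an unsubstituted 1H-indol-1-yl group or a 4-chloro-1H-indol-1-yl group would help to separate. Also open, from the compounds shown here alone, is how the tetrazole behaves with an amine on its phenyl ring or with a longer chain.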